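Aminophenyl enones on a pyrazole core: methoxy count

The source may hold more compounds than are shown below. What is called first, only, known or untested is meant among the compounds shown, and "the series" means these compounds.

Measured in a functional assay on UO-31 cells (Homo sapiens) for cytotoxicity, read by sulforhodamine B assay, with a stated time of 48 h, tested at 1 uM; on this read-out higher numbers stand for a weaker effect at the one concentration tested and lower numbers for a stronger effect:
compound 1 `COc1ccc(-c2cc(/C=C/C(=O)c3ccc(N)cc3)[nH]n2)cc1` gives 61%
compound 2 `COc1cc(-c2cc(/C=C/C(=O)c3ccc(N)cc3)[nH]n2)cc(OC)c1OC` gives 71%
compound 3 `COc1cc(-c2cc(/C=C/C(=O)c3ccc(F)c(F)c3)[nH]n2)cc(OC)c1OC` gives 84%

Compound 2 stands second highest of the three; compound 1 lies within the scatter of it, compound 3 beyond it, the step of a number 13 percentage points higher from compound 2 to compound 3 (beyond the scatter) on the carbonyl side. Compound 4 `COc1ccc(-c2cc(/C=C/C(=O)c3ccc(N)cc3)[nH]n2)cc1OC` is not yet measured. It differs from compound 2 by hydrogen in place of methoxy on an aromatic carbon on the aryl side of the core. Among the measured compounds shown here, no measured step touches that side; compound 1 and compound 2 differ there but only in a way not counted as one step, and their values lie within the scatter. Compound 4 is therefore expected to fall near compound 2, with a number 5 percentage points lower from compound 2 to compound 4 (within the scatter) not beyond the scatter. Compound 4 is estimated at 66%, range 50% to 82%.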

Compound 4, a percentage reported as activity, at one concentration (the size of the read-out at that concentration, not a potency): 86%
Estimate against measurement, compound 4: 20 percentage points below, outside the stated range (above it).
By their numbers in this assay, from the lowest: compounds 1 and 2 (each within the scatter of the next); then compounds 3 and 4 (each within the scatter of the next).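

Methoxy changes on this aromatic ring matter in this assay and act in the same direction whether a methoxy leaves or enters: hydrogen in place of methoxy gives a number 15 percentage points higher from compound 2 to compound 4 (beyond the scatter) and methoxy in place of hydrogen gives a number 25 percentage points higher from compound 1 to compound 4 (beyond the scatter) in a weaker effect at the one concentration tested. Methoxy count therefore gives no steady trend across compound 1, compound 4 and compound 2. Nothing at hand accounts for this reversal.

Open, on these data alone, is how a hydroxyl or ethoxy group would read on this aromatic carbon. Also open, as far as these compounds go, is whether these methoxy steps hold with 3,4-difluorophenyl on the carbonyl.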